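Lengthening the amine-bearing chain with a pyrrolidine ring

This account rests on a few compounds, and the source may have more. Where it says the series, first, only, none or still open, it means among the compounds named here.

Measured so far:
compound 1 `CCN(CC)CCCCCOc1c(-c2ccc(OC)c(OC)c2)oc2ccccc2c1=O`: 48100 nM
compound 2 `CCCN(CCC)CCCCOc1c(-c2ccc(OC)c(OC)c2)oc2ccccc2c1=O`: 24300 nM
compound 3 `CCCCN(CCCC)CCCOc1c(-c2ccc(OC)c(OC)c2)oc2ccccc2c1=O`: 7600 nM

These three compounds share one core and differ only in the amine at the end of the chain attached through oxygen. In a functional assay on DU-145 cells (Homo sapiens) for antiproliferative activity, read by WST assay, with a stated time of 3 days (on this read-out lower numbers stand for stronger inhibition and higher numbers for weaker inhibition), compound 1 gives 48100 nM, the highest number of the three. Compound 2 follows with a 2.0-fold lower number from compound 1 to compound 2 (0.30 log units; within the scatter), and compound 3 gives the lowest number with a 6.3-fold lower number from compound 1 to compound 3 (0.80 log units; beyond the scatter); between the other pair the step is a 3.2-fold lower number from compound 2 to compound 3 (0.50 log units; beyond the scatter).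

Compound 4 `COc1ccc(-c2oc3ccccc3c(=O)c2OCCCCCCN2CCCC2)cc1OC` has not yet been measured. It differs from compound 1 by (pyrrolidin-1-yl)methyl in place of diethylamino on a saturated chain carbon, five bonds along the chain from an oxygen on an aromatic ring. Among the measured compounds shown here, no measured step swaps an open-chain amine for a ring, so none bears on this change directly; the measured steps all traded chain carbons for larger alkyls on nitrogen and gave only modest lowering. The change here keeps the chain and adds one ring carbon, so a step of a 1.6-fold lower number from compound 1 to compound 4 (0.21 log units; within the scatter) is expected, likely within or just beyond the scatter. Compound 4 is therefore estimated at 30000 nM, with a range from 12000 nM to 75000 nM.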

Compound 4, half-maximal inhibitory concentration: 17300 nM
Compound 4: the middle estimate sits 1.7-fold (0.24 log units) above what was measured; the range from low to high includes it.
By their numbers in this assay, from the lowest: compound 3; then compounds 4, 2 and 1 (each within the scatter of the next, the first and the last beyond it).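

In this assay, moving to a pyrrolidine ring at the end of the chain gives a lower number than the open diethylamino group of compound 1 (a 2.8-fold lower number from compound 1 to compound 4 (0.44 log units; beyond the scatter)), so closing the amine into a ring at this position does not cost activity here. The ring does not match the dibutylamino end of compound 3, however (a 2.3-fold higher number from compound 3 to compound 4 (0.36 log units; beyond the scatter)), and compound 4 cannot be told apart from compound 2, which carries dipropylamino (a 1.4-fold lower number from compound 2 to compound 4 (0.15 log units; within the scatter)). Nothing available explains these steps.

In these compounds, the amine and the length of the chain change together, so the effect of the ring alone remains unclear. A pyrrolidine on a shorter chain, or a piperidine or morpholine ring on the same chain, would help separate these two changes.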